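The compounds below may be only part of what the source reports. "The series", "measured", "known", "first", "only" and "open" are said of these compounds alone.

Measured so far:
- compound 1 `CCOCc1cccc2c1CCC2c1ncc[nH]1`: 64% in a functional assay on CHO cells for agonist activity at Alpha-1A adrenergic receptor (Homo sapiens), read by fluorescence and calcium flux; a lower number here means a smaller maximal response, a higher number a larger maximal response
- compound 2 `COCc1ccc(F)c2c1CCC2c1ncc[nH]1`: 49% in this assay

Compound 1 has the higher of the two numbers in this assay; compound 2 sits below it by a gap that lies beyond the usual scatter of this kind of measurement. The two compounds differ in more than one place, so their gap cannot be tied to a single change.

Compound 3 `Fc1ccn(Cc2cccc3c2CCC3c2ncc[nH]2)n1` is not yet measured. It comes from compound 1 by one change, 3-fluoro-1H-pyrazol-1-yl in place of ethoxy on a saturated chain carbon bound to an aromatic carbon: a larger group with a five-membered aromatic ring takes the place of a small chain. Within the data shown here, no measured pair shows what such a swap does here, so the expectation for the step from compound 1 to compound 3 is a modest drop, about the size of the gap between compound 1 and compound 2, though a result within the scatter would not be surprising; this expected step is a number 10 percentage points lower from compound 1 to compound 3 (within the scatter). For compound 3 the estimated maximal response in this assay is 54%, with a range from 34% to 74%.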

Compound 3, largest response reached (Emax), in percent of the reference or control that the assay uses in the Alpha-1A adrenergic receptor assay: 83%
Beside the measured number, compound 3's estimate is 29 percentage points below it, outside the stated range (above it).
By their numbers in the Alpha-1A adrenergic receptor assay, from the lowest: compound 2; then compound 1; then compound 3.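

In the Alpha-1A adrenergic receptor assay the saturated chain carbon bound to an aromatic carbon accepts a larger group with a five-membered aromatic ring: 3-fluoro-1H-pyrazol-1-yl in place of ethoxy gives a number 19 percentage points higher from compound 1 to compound 3 (beyond the scatter), the only single-change step shown. In a physicochemical assay for lipophilicity, at pH 7.4 (a lower number here means a more polar compound, a higher number a more lipophilic compound), compound 1 gives 2.1 and compound 3 gives 2.4, two values within the usual scatter of each other, so the larger maximal response comes with no clear difference in this read-out. Nothing measured here offers a reason for the step.

This single step cannot separate the share of the fluorine from that of the ring or of the larger group. How a 1H-pyrazol-1-yl without fluorine, or an amine such as dimethylamino, would fare on the same carbon remains an open question.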